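Swapping the aryl group on the ring nitrogen

A few compounds are considered here, and "the series" means these few. Any claim that something is new, unique, unknown or untested is made for them only; others in the source may bear on it.

Values in a functional assay on HL-60 cells (Homo sapiens) for inhibition, read by MTT assay, with a stated time of 72 h; on this read-out higher numbers stand for weaker inhibition and lower numbers for stronger inhibition:
- compound 1 `Cc1nc(-c2ccccc2)c(C(=O)N2CCN(c3cc(Cl)cc(Cl)c3)CC2)o1`: 41.8 nM
- compound 2 `Cc1nc(-c2ccccc2)c(C(=O)N2CCN(c3c(C)cccc3C)CC2)o1`: 146 nM

Compound 2 has the higher of the two numbers, at 146 nM, and so the weaker inhibition. Compound 3 `Cc1nc(-c2ccccc2)c(C(=O)N2CCN(c3cccc(C#N)c3)CC2)o1` is next: 3-cyanophenyl in place of 2,6-dimethylphenyl on an amine nitrogen in a ring. In words, 3-cyanophenyl takes the place of 2,6-dimethylphenyl on an amine nitrogen in a ring.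

Among the compounds with values here, only one measured step bears on this place: a 3.5-fold higher number from compound 1 to compound 2 (0.54 log units; beyond the scatter). This modest step lies beyond the scatter and shows that the group here can shift the number. Neither measured compound carries 3-cyanophenyl, so the direction remains uncertain. Compound 1 lacks 2,6-dimethylphenyl and gives 41.8 nM, which points towards a lower number in this assay. The expected change is modest: a 1.7-fold lower number from compound 2 to compound 3 (0.23 log units; within the scatter). For compound 3 the estimate is 85 nM, with an expected range of 30 nM to 240 nM.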

Compound 3, half-maximal inhibitory concentration: 39.6 nM
Beside the measured number, compound 3's estimate is 2.1-fold (0.33 log units) above it, and the stated range covers the measured number.
By their numbers in this assay, from the lowest: compounds 3 and 1 (each within the scatter of the next); then compound 2.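

In this assay, the step of a 3.7-fold lower number from compound 2 to compound 3 (0.57 log units; beyond the scatter) gives a second measured change at this amine nitrogen that lies beyond the scatter, so compound 2 is now set apart from two other aryl groups rather than one. The step of a 1.1-fold lower number from compound 1 to compound 3 (0.02 log units; within the scatter) shows that 3-cyanophenyl and 3,5-dichlorophenyl cannot be told apart on this read-out, even though the two groups share neither their substituents nor their number. The data offer no measured explanation for why compound 2 stands apart from the other two.

Within the data shown here, with only three aryl groups, it remains open whether the methyl groups themselves or their placement set compound 2 apart. Also open, as far as these compounds go, is how plain phenyl, a pyridyl ring or a benzyl group would read on this nitrogen.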